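Trimming One Chain of Compound 1

The compounds below may be only part of what the source reports. "The series", "measured", "known", "first", "only" and "open" are said of these compounds alone.

Going by the values given here, in a functional assay on T98G cells (Homo sapiens) for inhibition, read by colorimetric assay and MTT assay, with a stated time of 72 h (a higher number here means a weaker inhibitor, a lower number a stronger inhibitor), compound 1 (`C=CCCCCOc1ccccc1-c1cnc(OCCCC=C)n1C`) gives 3000 nM, the lower of the two numbers measured so far. Compound 2 (`C=CCCCCOc1ncc(-c2cccc(OC)c2OC)n1C`) gives 35000 nM, and that gap lies beyond the scatter. Compound 3 (`C=CCCCCOc1ccccc1-c1cnc(OC)n1C`) keeps the core of compound 1 and changes one place: hydrogen in place of but-3-en-1-yl on a saturated chain carbon bound to an oxygen on an aromatic ring. Put simply, this is hydrogen in place of but-3-en-1-yl on a saturated chain carbon bound to an oxygen on an aromatic ring, so pent-4-en-1-yl becomes methyl. Among the compounds with values here, no measured pair of compounds shows this change, so what follows is a judgement and not a reading. A moderate move toward a higher number, meaning a weaker inhibitor, seems likely, and the expected size is a 3.3-fold higher number from compound 1 to compound 3 (0.52 log units; beyond the scatter). For compound 3 the estimated value is 10000 nM, with an expected range from 3000 nM to 40000 nM.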

Compound 3, half-maximal inhibitory concentration: > 100000 nM
Compound 3 gave a limit, no number; the forecaster's own chance of this, stated with the estimate: 15%; middle value at least 10-fold (1.00 log units) away from the limit.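

In this assay compound 3 gives > 100000 nM as a limit of the assay and not as a number. Cutting pent-4-en-1-yl down to methyl, with the rest of the molecule unchanged, gives an at least 33-fold higher number from compound 1 to compound 3 (1.52 log units; beyond the scatter) as a large step, so what this position carries matters greatly, and the but-3-en-1-yl part that leaves accounts for much of the activity of compound 1 in this assay. Going by these compounds, because the reading for compound 3 is a limit, the full size of the loss stays unknown: the limit of > 100000 nM in this assay, at which 1 of the 3 values shown sits.

The compounds shown do not tell whether a short chain such as ethyl or propyl would keep part of the activity. They also leave open whether the double bond is needed, which a saturated butyl chain could test, and whether a longer chain or one ending in an amine would do better.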